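Moving the Pyridine Nitrogen in a Weak Antiproliferative Amide

The source may report more compounds than this note shows. Statements on the series, on what has been measured and on what is new or still open speak of the compounds shown alone.

Compound 1, `O=C(NCc1ccccc1)c1cc(Oc2ccc(/C=C/c3ccccn3)cc2)ccn1`, gives 27900 nM in a functional assay on HepG2 cells (Homo sapiens) for antiproliferative activity, read by CCK-8 assay, with a stated time of 48 h; on this read-out higher numbers stand for weaker inhibition and lower numbers for stronger inhibition.
Compound 2, `CC(C)NC(=O)c1cc(Oc2ccc(/C=C/c3ccccn3)cc2)ccn1`, gives > 100000 nM in this assay, which is a limit and not a number.

Compound 2 therefore stands at the limit of > 100000 nM in this assay, at which 1 of the 2 values shown sits. Going by the values given here, the single measured step, an at least 3.5-fold higher number from compound 1 to compound 2 (0.55 log units; beyond the scatter), changes the group on the amide nitrogen and pushes the number out to that limit.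

Compound 3, `CC(C)NC(=O)c1cc(Oc2ccc(/C=C/c3ccncc3)cc2)ccn1`, differs from compound 2 in one place: pyridin-4-yl in place of pyridin-2-yl on a double-bonded chain carbon bound to a double-bonded chain carbon. The measured step concerns the amide nitrogen and not the pyridine, so it does not bear on this change. Among the compounds with values here, with no step touching the pyridine, the expectation is for no shift beyond the scatter, that is a step that the limit leaves unreadable from compound 2 to compound 3. Compound 3 is accordingly estimated at 150000 nM, with a range from 60000 nM to 400000 nM, and most likely again reported only as a limit.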

Compound 3, half-maximal inhibitory concentration: 33700 nM
Compound 3: middle estimate off by 4.5-fold (0.65 log units), on the high side; measured number below the stated range.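

Swapping pyridin-2-yl for pyridin-4-yl on the ethenyl chain gives an at least 2.9-fold lower number from compound 2 to compound 3 (0.47 log units; beyond the scatter) in this assay. The earlier step concerned only the amide nitrogen, whereas this one shows that the read-out also responds at the pyridine, even though the two groups hold the same atoms, joined differently. The true size of this step cannot be read, only its minimum, because compound 2 stands at a limit: the limit of > 100000 nM in this assay, at which 1 of the 3 values shown sits.

Going by these compounds, it remains open how pyridin-3-yl or a plain phenyl group would behave at this place on the chain. On these data alone, it is also open whether pyridin-4-yl would lower the number to the same extent when paired with the benzyl group of compound 1, or with a longer chain or a cyclohexyl group on the amide nitrogen.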